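This account rests on a few compounds, and the source may have more. Where it says the series, first, only, none or still open, it means among the compounds named here.

Compound 1 `COc1ccc(CN2C(=O)C(=O)c3cc(OC(F)(F)F)ccc32)cc1` is the starting point here. Going by the values given here, in a functional assay on CHO cells for agonist activity at muscarinic acetylcholine receptor M5 (Homo sapiens), read by calcium flux (a lower number here means that less compound is needed, a higher number that more compound is needed for the effect), compound 1 gives 1100 nM, the lower of the two numbers measured so far. Among the compounds with values here, compound 2 `O=C1C(=O)N(Cc2ccc(-c3ccccc3)cc2)c2ccc(OC(F)(F)F)cc21` is its only measured neighbour; in this assay compound 2 gives 2700 nM. Within the data shown here, the single step between them, phenyl in place of methoxy on an aromatic carbon, brought a 2.5-fold higher number from compound 1 to compound 2 (0.39 log units; beyond the scatter), so replacing the small methoxy by a whole aromatic ring at that position cost potency, though only modestly.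

Compound 3 `O=C1C(=O)N(Cc2ccc(-c3ccc(Cl)nc3)cc2)c2ccc(OC(F)(F)F)cc21` changes the same position of compound 1: 6-chloropyridin-3-yl in place of methoxy on an aromatic carbon. Among the measured compounds shown here, the 6-chloropyridin-3-yl ring is again a six-membered aromatic ring at the place where compound 2 carries phenyl, so the step from compound 1 to compound 2 is the only measured guide. For the measured compounds named here, because that step gave a 2.5-fold higher number from compound 1 to compound 2 (0.39 log units; beyond the scatter), a higher number of similar size is expected for compound 3, with the chlorine and the ring nitrogen adding uncertainty but no measured precedent. Compound 3 is therefore estimated to give 2500 nM in this assay, between 1000 nM and 6500 nM, which would be a step of a 2.3-fold higher number from compound 1 to compound 3 (0.36 log units; beyond the scatter).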

Compound 3, half-maximal effective concentration: 4800 nM
Compound 3: middle estimate off by 1.9-fold (0.28 log units), on the low side, within the range that was stated.
By their numbers in this assay, from the lowest: compound 1; then compounds 2 and 3 (each within the scatter of the next).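

With a second aromatic ring at this position the picture becomes firmer: in this assay, 6-chloropyridin-3-yl in place of methoxy gave a 4.4-fold higher number from compound 1 to compound 3 (0.64 log units; beyond the scatter) and so both rings shown, phenyl and 6-chloropyridin-3-yl, stand on the higher-number side of methoxy, with no compound here going against that. Exchanging one ring for the other gave a 1.8-fold higher number from compound 2 to compound 3 (0.25 log units; within the scatter) and that step lies within the scatter, so the ring nitrogen and the chlorine, taken together, make no readable difference from plain phenyl. No measurement at hand speaks to the reason behind these steps.

As far as these compounds go, whether the chlorine or the ring nitrogen would matter on its own stays open, since the two arrive together in compound 3. Also open, from the compounds shown here alone, is how groups of a different kind at this position, such as an amine, a carboxylic acid or a longer alkoxy chain, would compare with methoxy, and whether any group there could bring a lower number than methoxy does in compound 1.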